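This account rests on a few compounds, and the source may have more. Where it says the series, first, only, none or still open, it means among the compounds named here.

Compound 1, `Nc1nc(NCc2ccccc2)c2ncn(/C=C3/CC3(CO)CO)c2n1` — in an ADME assay on MOLT-3 cells (Homo sapiens) for cytotoxicity, with a stated time of 7 days (a higher number here means that more compound is tolerated, a lower number that less compound is tolerated), compound 1 gives > 20000 nM, which is a limit of the assay.
Compound 2, `Nc1nc(NC2CC2)c2ncn(/C=C3/CC3(CO)CO)c2n1` — compound 2 gives > 20000 nM, again a limit.
Compound 3, `CCCCCCCCSc1nc(N)nc2c1ncn2/C=C1/CC1(CO)CO` — compound 3 gives > 20000 nM, also a limit.

Compound 1 therefore stands only at a limit, and the same holds for the two other measured compounds. The steps among them, a step that the two limits leave unreadable from compound 1 to compound 2, a step that the two limits leave unreadable from compound 1 to compound 3 and a step that the two limits leave unreadable from compound 2 to compound 3, cannot be read in size for that reason. The one point the data establish is the limit of > 20000 nM in this assay, at which 3 of the 3 values shown sit.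

Compound 4, `Nc1nc(SCc2ccccc2)c2ncn(/C=C3/CC3(CO)CO)c2n1`, differs from compound 1 in a single place: benzylsulfanyl in place of benzylamino on an aromatic carbon. Among the compounds with values here, none of the measured steps changes the same part of the core in the same way, so none bears directly on this step; what they do show is that exchanges of the group on this aromatic carbon, and of the group on the nitrogen attached to it, all left the compounds at the limit. On that basis compound 4 is expected to remain at the limit as well, and the estimated step that the limit leaves unreadable from compound 1 to compound 4 is therefore taken as none beyond the scatter. The estimate for compound 4 in this assay is 25000 nM, within a range from 10000 nM to 60000 nM.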

Compound 4, half-maximal cytotoxic concentration: > 20000 nM
Compound 4 ended at the assay's limit (the forecaster's own chance of this, stated with the estimate: 80%); the middle value is on the limit's open side.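

Within the data shown here, no step linking compound 4 to compound 1, compound 2 or compound 3 can be read in this assay, as all four compounds stand only at a limit: the limit of > 20000 nM in this assay, at which 4 of the 4 values shown sit. The compounds shown leave open how far each lies past that limit, and whether exchanging the group on the aromatic carbon changes how much compound is tolerated at all.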